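The compounds below may be only part of what the source reports. "The series", "measured", "known", "first", "only" and "open" are said of these compounds alone.

Measured compounds:
compound 1, `Cc1cc(Nc2ccn(Cc3cccc4ccccc34)n2)n2nc(SCc3ccc(Br)cc3)nc2n1`, 3240 nM
compound 2, `Cc1cc(Nc2cc(-c3ccccc3)[nH]n2)n2nc(SCc3ccc(F)cc3)nc2n1`, 3270 nM
compound 3, `Cc1cc(Nc2cc(-c3cccs3)[nH]n2)n2nc(SCc3ccc(Br)cc3)nc2n1`, 3770 nM

All three were read in a functional assay on MGC-803 cells (Homo sapiens) for inhibition, read by MTT assay, with a stated time of 72 h; on this read-out higher numbers stand for weaker inhibition and lower numbers for stronger inhibition. Compound 1 gives 3240 nM, compound 2 gives 3270 nM and compound 3 gives 3770 nM; the three numbers lie within the usual scatter of one another, so none of them can be set apart on this read-out.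

Compound 4, `COc1ccc(Cn2ccc(Nc3cc(C)nc4nc(SCc5ccc(Br)cc5)nn34)n2)cc1`, has not yet been measured in this assay. It differs from compound 1 in one place: 4-methoxyphenyl in place of naphthalen-1-yl on a saturated chain carbon bound to an aromatic nitrogen. Among the compounds with values here, no measured pair carries this change, so its effect is unknown. Given how little the three measured values spread, the step of a 1.2-fold higher number from compound 1 to compound 4 (0.09 log units; within the scatter) is expected to stay within the scatter, with no direction beyond it. Compound 4 is therefore estimated at 4000 nM, with a range from 1500 nM to 11000 nM.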

Compound 4, half-maximal inhibitory concentration: 12600 nM
For compound 4 the middle estimate is 3.2-fold (0.50 log units) below the measured one; measured number above the stated range.
By their numbers in this assay, from the lowest: compounds 1, 2 and 3 (each within the scatter of the next); then compound 4.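

In this assay this position proves sensitive to the group on the saturated chain carbon: 4-methoxyphenyl in place of naphthalen-1-yl gives a 3.9-fold higher number from compound 1 to compound 4 (0.59 log units; beyond the scatter) and so weaker inhibition. The earlier compounds shown here, with no pair differing in one place, could not show this. No evidence at hand accounts for the step.

The change removes one six-membered aromatic ring and adds a methoxy group together, and the compounds shown do not separate the two. Unsubstituted phenyl or naphthalen-2-yl on the same carbon remains an open comparison with compound 1.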